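The source may report more compounds than this note shows. Statements on the series, on what has been measured and on what is new or still open speak of the compounds shown alone.

In a functional assay on MDA-MB-231 cells (Homo sapiens) for inhibition, read by MTT assay, with a stated time of 72 h (on this read-out higher numbers stand for weaker inhibition and lower numbers for stronger inhibition), compound 1 `COC(=O)c1ccc(-n2cc(CCCNC(=O)c3ccc(C)cc3)nn2)cc1` gives > 100000 nM, which is a limit of the assay and not a number. Compound 2 `COC(=O)c1ccc(-n2cc(CCCOC(=O)c3ccc(C)cc3)nn2)cc1` gives > 100000 nM, again a limit. For the measured compounds named here, compound 3 `COC(=O)c1ccc(-n2cc(CCCNc3ccc(C)cc3)nn2)cc1` gives 33000 nM, the only true number among the three.

The next compound, compound 4 `COC(=O)c1ccc(-n2cc(CCCOc3ccc(C)cc3)nn2)cc1`, differs from compound 3 by 4-methylphenoxy in place of (4-methylphenyl)amino on a saturated chain carbon, three bonds along the chain from an aromatic carbon. The oxygen thus takes the place of the amine nitrogen, and the hydrogen-bond donor is lost. Going by the values given here, the one measured step that bears on this is an at least 3.0-fold lower number from compound 1 to compound 3 (0.48 log units; beyond the scatter), which lies beyond the scatter. It shows that removing the carbonyl from the nitrogen linker gives a measurable number, and compound 4 likewise lacks that carbonyl. That step does not swap nitrogen for oxygen, however, and compounds 1 and 2 both stop at the limit, so the size of such a swap remains unmeasured.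

Resting on compound 3 at 33000 nM, no clear change is expected, with only a slight lean towards a higher number. The expected size is a 1.4-fold higher number from compound 3 to compound 4 (0.13 log units; within the scatter), which is not expected to clear the scatter with any confidence. For compound 4 the estimate is 45000 nM, with an expected range from 15000 nM to 100000 nM.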

Compound 4, half-maximal inhibitory concentration: 14200 nM
Compound 4: middle estimate off by 3.2-fold (0.50 log units), on the high side; measured number below the stated range.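

In this assay, the exchange of (4-methylphenyl)amino for 4-methylphenoxy on this saturated chain carbon now has a measured size, with a 2.3-fold lower number from compound 3 to compound 4 (0.37 log units; beyond the scatter). The amine hydrogen is therefore not required for a measurable number here, as compound 4 carries 0 hydrogen-bond donors in this group and still gives the lower number of the pair. Taking away the carbonyl also lowers the number on the oxygen linker, as it did on the nitrogen linker, with an at least 7.0-fold lower number from compound 2 to compound 4 (0.84 log units; beyond the scatter); that step starts from a limit of the assay and not a number, so its full size cannot be read: the limit of > 100000 nM in this assay, at which 2 of the 4 values shown sit.

The compounds shown leave open whether this shift belongs to the oxygen itself, which a sulfur or a methylene at the same place in the chain would help to test. They also leave open how far the linker result carries over to a longer chain, to a chlorine in place of the methyl group of the 4-methylphenoxy, or to a carboxylic acid in place of the methyl ester.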